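The source may hold more compounds than are shown below. What is called first, only, known or untested is meant among the compounds shown, and "the series" means these compounds.

In a functional assay on KB cells (Homo sapiens) for inhibition (on this read-out higher numbers stand for weaker inhibition and lower numbers for stronger inhibition), compound 1 `N#CCSc1nc2cc(Cl)c(Cl)cc2n1C1O[C@H](CO)[C@@H](O)[C@H]1O` gives > 100000 nM, which is a limit of the assay and not a number. For the measured compounds named here, compound 2 `OC[C@H]1OC(n2c(SCc3ccc(Br)cc3)nc3cc(Cl)c(Cl)cc32)[C@H](O)[C@@H]1O` gives 20000 nM, the only actual number so far, so it has no second number to be ranked against. Going by the values given here, the one measured step, an at least 5.0-fold lower number from compound 1 to compound 2 (0.69 log units; beyond the scatter), put 4-bromophenyl in place of cyano on a saturated chain carbon bound to a sulfur. Compound 3 `OC[C@H]1OC(n2c(SCc3cccc(Cl)c3)nc3cc(Cl)c(Cl)cc32)[C@H](O)[C@@H]1O` changes that same place again, and the difference is 3-chlorophenyl in place of 4-bromophenyl on a saturated chain carbon bound to a sulfur. Here 3-chlorophenyl stands in place of 4-bromophenyl. The measured step bears on this only indirectly: it shows that the group at this place can shift the read-out, but it replaced cyano and not one halogen-bearing phenyl with another. Among the compounds with values here, with the step of an at least 5.0-fold lower number from compound 1 to compound 2 (0.69 log units; beyond the scatter) as the only guide, no step beyond the scatter is expected in this assay. The expected step is a 1.1-fold higher number from compound 2 to compound 3 (0.04 log units; within the scatter). Compound 3 is estimated at 22000 nM, with an expected range from 9000 nM to 60000 nM.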

Compound 3, half-maximal inhibitory concentration: 19000 nM
Compound 3: the middle estimate sits 1.2-fold (0.06 log units) above what was measured; low and high end bracket the measured number.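

In this assay, compound 3 puts a second halogen-bearing phenyl group on the saturated chain carbon bound to a sulfur, and a 1.1-fold lower number from compound 2 to compound 3 (0.02 log units; within the scatter) shows that 3-chlorophenyl in place of 4-bromophenyl gives no change beyond the scatter. The other new step, an at least 5.2-fold lower number from compound 1 to compound 3 (0.72 log units; beyond the scatter), shows that the lower number seen on leaving cyano is not tied to 4-bromophenyl alone, since it also appears with 3-chlorophenyl, although only these two phenyl groups bear on that reading. Compound 1 carries a limit and not a number, so each step from it is a bound and its full size cannot be read: the limit of > 100000 nM in this assay, at which 1 of the 3 values shown sits.

Because 4-bromophenyl and 3-chlorophenyl differ in both the halogen and its numbered place on the ring, the compounds shown leave open what each of these changes does alone, which 4-chlorophenyl or 3-bromophenyl would help to separate. Also open, from the compounds shown here alone, is how the read-out responds to plain phenyl, an amine or a carboxylic acid at this place, or to a longer chain carrying the phenyl group on the sulfur.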